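The source may report more compounds than this note shows. Statements on the series, on what has been measured and on what is new or still open speak of the compounds shown alone.

Measured compounds:
compound 1 `COc1ccc(S(=O)(=O)NCCCCCCNCc2ccc(Br)cc2)cc1`: 13000 nM
compound 2 `O=S(=O)(NCCCCCCNCc1ccc(Br)cc1)c1ccccc1F`: 13300 nM

In a functional assay on MIA PaCa-2 cells (Homo sapiens) for inhibition, read by MTT assay, with a stated time of 72 h (a higher number here means a weaker inhibitor of growth, a lower number a stronger inhibitor of growth), compound 2 gives 13300 nM, the higher of the two numbers, and its nearest neighbour compound 1 gives 13000 nM, a gap within the scatter. Compound 3 `O=S(=O)(NCCCCCCNCc1ccc(Br)cc1)c1ccc2ccsc2c1` carries 1-benzothiophen-6-yl in place of 2-fluorophenyl on a sulfonyl sulfur. Among the compounds with values here, the one step that bears on this place, a 1.0-fold higher number from compound 1 to compound 2 (0.01 log units; within the scatter), also exchanged the group on the sulfonyl sulfur and stayed within the scatter. On that basis no change beyond the scatter is expected for compound 3, and its estimate in this assay is 10000 nM, between 3500 nM and 28000 nM, which is expected to mean a step of a 1.3-fold lower number from compound 2 to compound 3 (0.12 log units; within the scatter).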

Compound 3, concentration for 50% growth inhibition: 6000 nM
Compound 3: the middle estimate sits 1.7-fold (0.22 log units) above what was measured, and the stated range covers the measured number.
By their numbers in this assay, from the lowest: compound 3; then compounds 1 and 2 (each within the scatter of the next).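

In this assay, the group on the sulfonyl sulfur now shows an effect on the number: exchanging 4-methoxyphenyl for 2-fluorophenyl had left it within the scatter (a 1.0-fold higher number from compound 1 to compound 2 (0.01 log units; within the scatter)), whereas 1-benzothiophen-6-yl gives a modest change beyond it (a 2.2-fold lower number from compound 2 to compound 3 (0.35 log units; beyond the scatter)) and (a 2.2-fold lower number from compound 1 to compound 3 (0.34 log units; beyond the scatter)). So this position is not indifferent to its group, at least among these three compounds. No measurement here explains the change.

On these data alone, whether the fused second ring or its sulfur matters stays open, and a naphthalen-2-yl group, built of carbon only, would separate the two. As far as these compounds go, how a pyridin-3-yl group would read here is also open.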